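A few compounds are considered here, and "the series" means these few. Any claim that something is new, unique, unknown or untested is made for them only; others in the source may bear on it.

Compound 2 `C#Cc1cn([C@@H]2O[C@H](CO)[C@@H](O)[C@H]2O)c2ncnc(N(C)C)c12` sits at the lower end of the numbers shown: in a functional assay on HCT-116 cells (Homo sapiens), read by MTT assay, with a stated time of 72 h (a higher number here means a weaker inhibitor, a lower number a stronger inhibitor), compound 2 gives 180 nM, and compound 1 `C#Cc1cn([C@@H]2O[C@H](CO)[C@@H](O)[C@H]2O)c2ncnc(OC)c12` gives 4060 nM. Compound 3 `Cc1ncnc2c1c(-c1cc3ccccc3o1)cn2[C@@H]1O[C@H](CO)[C@@H](O)[C@H]1O` gives only a limit in this assay, > 20000 nM. Within the data shown here, the one measured step, a 23-fold lower number from compound 1 to compound 2 (1.35 log units; beyond the scatter), concerns the dimethylamino group and not the position changed here. Compound 4 `CN(C)c1ncnc2c1c(-c1ccsc1)cn2[C@@H]1O[C@H](CO)[C@@H](O)[C@H]1O` differs from compound 2 by thiophen-3-yl in place of ethynyl on an aromatic carbon. Among the measured compounds shown here, no measured step bears on this change; compound 3 carries a different group at that position and a methyl elsewhere, so its limit cannot be read as a step. Compound 4 is therefore expected near 500 nM, between 60 nM and 4000 nM, a step of a 2.8-fold higher number from compound 2 to compound 4 (0.44 log units; beyond the scatter) that is uncertain.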

Compound 4, half-maximal inhibitory concentration: > 20000 nM
Compound 4 gave a limit, no number; the forecaster's own chance of this, stated with the estimate: 10%; at least 40-fold (1.60 log units) between middle value and limit.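

Among these compounds, with the dimethylamino group held constant, the change to thiophen-3-yl gives the first measured step at this position in this assay: an at least 110-fold higher number from compound 2 to compound 4 (2.04 log units; beyond the scatter). Ethynyl at this aromatic carbon therefore cannot be exchanged for this five-membered aromatic ring without a large loss in this assay. Compound 4 gives a limit and not a number, so the true size of the step stays unknown, and compound 3, which differs in more than one place, reaches the same limit: the limit of > 20000 nM in this assay, at which 2 of the 4 values shown sit.

Going by these compounds, whether any replacement for ethynyl at this carbon keeps a measurable number stays open, for a nitrile, for example, or a longer chain ending in a triple bond. On these data alone, it is also open whether a smaller ring, such as cyclopropyl, would fare better than thiophen-3-yl.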